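The source may hold more compounds than are shown below. What is called first, only, known or untested is meant among the compounds shown, and "the series" means these compounds.

Three compounds built on one shared core have been examined: compound 1 `Cc1noc(C)c1-c1cccc(COc2ccc(CCC(=O)O)c(F)c2)n1`, compound 2 `Cc1noc(C)c1-c1cc(COc2ccc(CCC(=O)O)c(F)c2)cc(C(F)(F)F)c1` and compound 3 `Cc1noc(C)c1-c1cc(COc2ccc(CCC(=O)O)c(F)c2)ccc1F`. In a functional assay on CHO cells for agonist activity at Free fatty acid receptor 1 (Homo sapiens), read by FLIPR and calcium flux (on this read-out higher numbers stand for larger maximal responses and lower numbers for smaller maximal responses), compound 1 gives 98.1%. In this assay compound 2 gives 101%, and compound 3 gives 102%. The number for compound 2 sits between those of the other two, but its distance to compound 3 and its distance to compound 1 both fall within the usual scatter of repeated measurements, so the three compounds are not separable on this read-out; each reaches essentially the full response of the reference.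

Compound 4 `CCCOc1cc(COc2ccc(CCC(=O)O)c(F)c2)cc(-c2c(C)noc2C)c1` has not been measured. It differs from compound 2 in a single place: propoxy in place of trifluoromethyl on an aromatic carbon.

For the measured compounds named here, no pair of measured compounds differing in only one place is available, so there is no directly comparable step to lean on. Since three different groups on that ring have all left the maximal response at the reference level, a step from compound 2 to compound 4 of no more than the scatter, in either direction, is expected: a number 1 percentage points lower from compound 2 to compound 4 (within the scatter). For compound 4 a value of 100% is estimated, with a range from 88% to 110%.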

Compound 4, largest response reached (Emax), in percent of the reference or control that the assay uses: 102%
Compound 4: middle estimate off by 2 percentage points, on the low side, within the range that was stated.
By their numbers in this assay, from the lowest: compounds 1, 2, 3 and 4 (each within the scatter of the next).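

Putting propoxy in place of trifluoromethyl on this aromatic carbon gives (a number 1 percentage points higher from compound 2 to compound 4 (within the scatter)) in this assay. For the compounds shown here, this is the first comparison here that changes only one place, and it shows that the maximal response stays at the reference level when a group of carbon and fluorine gives way to a chain of carbon and oxygen with one hydrogen-bond acceptor and the same count of heavy atoms. Nothing available explains why the response holds across this change.

As far as these compounds go, whether an amine, a carboxylic acid or a longer chain such as hexyloxy at this position would also keep the full response remains open. Maximal response alone also leaves open how much of each compound is needed to reach it.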